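Inverting one ring stereocentre of compound 1

The source may report more compounds than this note shows. Statements on the series, on what has been measured and on what is new or still open speak of the compounds shown alone.

Going by the values given here, in a functional assay on Vero cells (Chlorocebus sabaeus) for inhibition (a higher number here means a weaker inhibitor, a lower number a stronger inhibitor), compound 1 (`Nc1nc(F)nc2c1ncn2[C@H]1CS[C@@H](CO)O1`) gives 5600 nM as the only actual number so far. Compound 2 (`Cc1cn([C@@H]2CS[C@@H](CO)O2)c(=O)[nH]c1=O`) sits at a limit of the assay, not a number: > 100000 nM is all it shows. Compound 3 (`Nc1nc(F)nc2c1ncn2[C@@H]1CS[C@@H](CO)O1`) is the unmeasured partner of compound 1, and the two compounds have the same atoms and bonds and differ only in configuration as drawn: 1 of 2 stereo elements differ; a stereocentre at a saturated ring carbon is drawn R in compound 1 and S in compound 3 is the whole of the change. Among the compounds with values here, no measured step gauges such an inversion, so the size is a judgement. The expected step is a 2.7-fold higher number from compound 1 to compound 3 (0.43 log units; beyond the scatter) toward weaker inhibition in this assay with wide uncertainty. Compound 3 is estimated at 15000 nM with an expected range from 2500 nM to 100000 nM for its reading.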

Compound 3, half-maximal inhibitory concentration: 45400 nM
Compound 3: middle estimate off by 3.0-fold (0.48 log units), on the low side; low and high end bracket the measured number.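

In this assay, inverting the ring stereocentre gives an 8.1-fold higher number from compound 1 to compound 3 (0.91 log units; beyond the scatter), the first measured size for this change in the series. Compound 3 still gives a number rather than a limit of the assay, so inhibition weakens at this centre but remains readable. The step can be assigned to this one saturated ring carbon because nothing else changes: the fact that compounds 1 and 3 differ only in the configuration as drawn

Open, going by these compounds, is whether inverting the other stereocentre moves the number as far. Also open, on these data alone, is whether a step of this size holds with a carboxylic acid on the shared core.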